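The source may report more compounds than this note shows. Statements on the series, on what has been measured and on what is new or still open speak of the compounds shown alone.

Measured compounds in a functional assay on PBMC cells (Homo sapiens) for inhibition; a higher number here means a weaker inhibitor, a lower number a stronger inhibitor:

compound 1 `CC(C)C[C@H](N)C(=O)NS(=O)(=O)OC[C@H]1OC[C@@H](n2cnc3c(N)ncnc32)[C@H](O)[C@@H]1O` gives 1000 nM
compound 2 `CC[C@H](C)[C@H](N)C(=O)NS(=O)(=O)OC[C@H]1O[C@@H](n2cnc3c(N)ncnc32)[C@H](O)[C@@H]1O` gives 5600 nM
compound 3 `CC(C)C[C@H](N)C(=O)NS(=O)(=O)OC[C@H]1OC[C@@H](n2cnc3c(N)ncnc32)C[C@@H]1O` gives 6800 nM

Compound 2 stands second highest of the three numbers. Its nearest neighbour is compound 3, whose value lies within the scatter of that of compound 2; the furthest is compound 1, whose lower number lies beyond the scatter. Compound 1 and compound 2 differ in more than one place, so their values show only that gap and no single change. Among the measured compounds shown here, the one step between compounds differing in one place, a 6.8-fold higher number from compound 1 to compound 3 (0.83 log units; beyond the scatter), concerns hydrogen in place of hydroxy on a saturated ring carbon and does not touch the side chain.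

Compound 4 `CSCC[C@H](N)C(=O)NS(=O)(=O)OC[C@H]1O[C@@H](n2cnc3c(N)ncnc32)[C@H](O)[C@@H]1O` is the next compound. The change from compound 2 is 2-(methylsulfanyl)ethyl in place of sec-butyl on a saturated chain carbon bound to an amine nitrogen and a carbonyl carbon. For the measured compounds named here, no measured step bears on this change; the side chain is varied only together with the core among the three measured compounds. In this assay the expected step is therefore a 1.1-fold lower number from compound 2 to compound 4 (0.05 log units; within the scatter), with no direction supported beyond the scatter. Compound 4 is estimated at 5000 nM, within 1500 nM to 16000 nM.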

Compound 4, half-maximal inhibitory concentration: 500 nM
The estimate for compound 4 lay 10-fold (1.00 log units) above the measured number; the whole stated range lies above it.
By their numbers in this assay, from the lowest: compounds 4 and 1 (each within the scatter of the next); then compounds 2 and 3 (each within the scatter of the next).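

In this assay, among the compounds shown here, the side chain on the saturated chain carbon bound to an amine nitrogen and a carbonyl carbon matters on its own: 2-(methylsulfanyl)ethyl in place of sec-butyl gives an 11-fold lower number from compound 2 to compound 4 (1.05 log units; beyond the scatter), the first step here that leaves the core unchanged. The two groups have the same heavy-atom count, but sulfur enters in place of a carbon, a hydrogen-bond acceptor is gained and a defined stereocentre is lost, and this pair cannot separate these differences. No available measurement explains the step.

Going by these compounds, it remains open whether 2-(methylsulfanyl)ethyl gives a similar step on the core of compound 1 or compound 3. Also open, on these data alone, is how the value responds at this position to 2-methoxyethyl, which would test the sulfur directly, or to a longer chain, an amine or a carboxylic acid.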